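The source may hold more compounds than are shown below. What is called first, only, known or untested is meant among the compounds shown, and "the series" means these compounds.

The measured compounds:
compound 1, `CCC1=C(O)c2c(oc(-c3ccc(CC)cc3)cc2=O)C(CC)(CC)C1=O`, giving 0.07 uM in a functional assay on KBVIN cells (Homo sapiens) for antiproliferative activity, read by sulforhodamine B assay, with a stated time of 3 days; a lower number here means that less compound is needed, a higher number that more compound is needed for the effect;
compound 2, `CCCc1ccc(-c2cc(=O)c3c(o2)C(CC)(CC)C(=O)C(CC)=C3O)cc1`, giving 12.2 uM;
compound 3, `CCC1=C(O)c2c(oc(-c3ccc(OC)cc3)cc2=O)C(CC)(CC)C1=O`, giving 0.68 uM.

Among these three, compound 1 has the lowest number in this assay. The nearest of the others is compound 3, reached by a 9.7-fold higher number from compound 1 to compound 3 (0.99 log units; beyond the scatter), and the furthest is compound 2, reached by a 170-fold higher number from compound 1 to compound 2 (2.24 log units; beyond the scatter), so compound 1 stands clearly apart from both.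

Compound 4, `CCC1=C(O)c2c(oc(-c3ccc(C)c(C)c3)cc2=O)C(CC)(CC)C1=O`, is not yet measured. It differs from compound 1 in one place: 3,4-dimethylphenyl in place of 4-ethylphenyl on an aromatic carbon. The same atoms are present in both, joined differently.

For the measured compounds named here, two measured steps bear on this change, both starting from compound 1 and both altering the same phenyl group. The step of a 170-fold higher number from compound 1 to compound 2 (2.24 log units; beyond the scatter) shows that lengthening the chain on that phenyl ring by a single carbon costs a great deal. The step of a 9.7-fold higher number from compound 1 to compound 3 (0.99 log units; beyond the scatter) shows that exchanging the ethyl for methoxy costs less, but still beyond the scatter. Every departure from the 4-ethylphenyl seen so far raised the number, so a rise is expected for compound 4 as well, most likely of modest size, written as a 7.1-fold higher number from compound 1 to compound 4 (0.85 log units; beyond the scatter). Compound 4 is therefore estimated at 0.5 uM, with a range from 0.1 uM to 3 uM.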

Compound 4, concentration for half-maximal effect: 0.71 uM
Compound 4: the middle estimate sits 1.4-fold (0.15 log units) below what was measured; the range from low to high includes it.
By their numbers in this assay, from the lowest: compound 1; then compounds 3 and 4 (each within the scatter of the next); then compound 2.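

In this assay, rearranging the carbons of the 4-ethylphenyl into 3,4-dimethylphenyl leaves the atoms unchanged yet gives a 10-fold higher number from compound 1 to compound 4 (1.01 log units; beyond the scatter), so the low number of compound 1 depends on how these atoms are joined and not merely on which atoms are present. The 3,4-dimethylphenyl and 4-methoxyphenyl groups cannot be told apart at this position, with a 1.0-fold higher number from compound 3 to compound 4 (0.02 log units; within the scatter), even though they differ in their atoms, so two quite different groups can give the same level here. The 3,4-dimethylphenyl also stands well clear of the 4-propylphenyl, with a 17-fold lower number from compound 2 to compound 4 (1.24 log units; beyond the scatter), so among the four groups seen on this aromatic carbon, 4-ethylphenyl alone sets its compound apart at the low end and 4-propylphenyl alone at the high end.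

Nothing measured alongside these numbers accounts for the differences between the four groups. As far as these compounds go, it remains open how an unsubstituted phenyl, or a phenyl ring carrying an amine or a carboxylic acid, would compare with 4-ethylphenyl on this carbon, and whether the same order holds when other parts of the shared core are changed.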